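The compounds below may be only part of what the source reports. "The series", "measured", "known", "first", "only" and "open" are said of these compounds alone.

In an ADME assay on S9 fraction from liver (Rattus norvegicus) for metabolic stability, with a stated time of 1 h (on this read-out higher numbers stand for a more stable compound and lower numbers for a less stable compound), two compounds sharing one core have been measured. Compound 1 `N#Cc1cnc(NCc2ccccc2C(F)(F)F)cc1N[C@H]1CC[C@@H](O)CC1` gives 31%, and compound 2 `N#Cc1cnc(NCc2ccccc2C(F)(F)F)cc1N[C@H]1C[C@H](C(N)=O)C1` gives 54%, the higher of the two numbers. Compound 3 `N#Cc1cnc(NCc2ccccc2C(F)(F)F)cc1N[C@H]1CC[C@@H](C(N)=O)CC1` has not yet been measured. It differs from compound 2 in one place: 4-carbamoylcyclohexyl in place of 3-carbamoylcyclobutyl on a nitrogen on an aromatic ring. In words, 4-carbamoylcyclohexyl stands in place of 3-carbamoylcyclobutyl on a nitrogen on an aromatic ring.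

Among the measured compounds shown here, only one measured step bears on this change: a number 23 percentage points higher from compound 1 to compound 2 (beyond the scatter), a modest rise beyond the scatter. That step, from 4-hydroxycyclohexyl to 3-carbamoylcyclobutyl, altered the ring and the group on it together, and the data cannot separate the two. Compound 3 keeps the carbamoyl group of compound 2, at 54%, and the six-membered ring of compound 1, at 31%, so a value between those two is expected. The expected change is a number 11 percentage points lower from compound 2 to compound 3 (beyond the scatter), a fall smaller than the measured step. For compound 3 the estimated value is 43%, with an expected range from 25% to 62%.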

Compound 3, percent of the compound remaining: 3%
Estimate against measurement, compound 3: 40 percentage points above, and the stated range ends above it.
By their numbers in this assay, from the lowest: compound 3; then compound 1; then compound 2.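

In this assay, holding the carbamoyl group fixed and changing only the ring that carries it gives a number 51 percentage points lower from compound 2 to compound 3 (beyond the scatter) and leaves compound 3 at the bottom of the three, so the ring on this nitrogen can shift the number strongly by itself. With the six-membered ring kept, carbamoyl in place of hydroxy gives a number 28 percentage points lower from compound 1 to compound 3 (beyond the scatter) on this read-out, which shows that the carbamoyl group brings no rise of its own: among these three compounds, it goes with the highest number on the 3-carbamoylcyclobutyl of compound 2 and the lowest on the 4-carbamoylcyclohexyl of compound 3. No measurement shown here offers a reason for either fall.

Still open, from the compounds shown here alone, is how a 3-hydroxycyclobutyl would stand at this nitrogen, a group that would show whether the four-membered ring also goes with a higher number when it carries hydroxy rather than carbamoyl. Equally open, going by these compounds, is how a five-membered carbon ring would compare, and whether an amine or a carboxylic acid on the ring would follow either of the groups seen so far.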